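This account rests on a few compounds, and the source may have more. Where it says the series, first, only, none or still open, it means among the compounds named here.

Three compounds share a core, and one further compound is considered here. Compound 1 `Nc1cc2ccccc2cc1NC(=O)c1ccc(CNc2nccc(-c3cccnc3)n2)cc1` was tested in an assay on isolated protein for inhibition of protein deacetylase HDAC6 (Homo sapiens), read by fluorescence, with stated times of 3 h and 60 min; a higher number here means a weaker inhibitor, a lower number a stronger inhibitor. Compound 1 gives > 20000 nM, which is a limit of the assay rather than a number. Compound 2 `Nc1ccccc1NC(=O)c1ccc(CNC2=N[C@H](Cc3ccccc3)CS2)cc1` gives > 20000 nM, again a limit of the assay and not a number. For compound 3 `Nc1ccccc1NC(=O)c1ccc(CNC2=NC[C@@H](c3ccccc3)S2)cc1` the entry in this assay reads "not determined" (no result reported), so no result is given. Within the data shown here, compound 1 thus stands at the edge of what the assay can report, and the only other value shown sits at the same edge; nothing here separates any two compounds. Compound 4 `Nc1cc(C(=O)O)ccc1NC(=O)c1ccc(CNc2nccc(-c3cccnc3)n2)cc1` has not been measured. It differs from compound 1 as follows: a group of 10 heavy atoms (7 carbon, 1 nitrogen, 2 oxygen; one six-membered aromatic ring of carbon only) in place of a group of 11 heavy atoms (10 carbon, 1 nitrogen; 2 six-membered aromatic rings of carbon only), on an amide-type nitrogen. Among the measured compounds shown here, no step between measured compounds is available, so the size of a step cannot be read from the data. Both values shown sit at the limit of > 20000 nM in this assay, at which 2 of the 3 values shown sit. Compound 4 is expected to sit there too, with a number no higher from compound 1 to compound 4 (the limit leaves the size open) not beyond the usual scatter. Compound 4 is therefore estimated at 20000 nM, between 6000 nM and 60000 nM.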

Compound 4, half-maximal inhibitory concentration: > 20000 nM
Compound 4 ended at the assay's limit; the forecaster's own chance of this, stated with the estimate: 70%; the middle value lies on the limit itself.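

Among these compounds, compound 1 and compound 4 both stand at the edge of what this assay can report, so no step between them can be read: the limit of > 20000 nM in this assay, at which 3 of the 4 values shown sit.

The compounds shown leave open what real value any of them has in this assay and which change to the shared core would give a reading inside the limit.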